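The source may report more compounds than this note shows. Statements on the series, on what has been measured and on what is new or still open speak of the compounds shown alone.

For the measured compounds named here, in a functional assay on HT-29 cells (Homo sapiens) for cytotoxicity, read by MTT assay, with a stated time of 72 h (a lower number here means a stronger inhibitor of growth, a higher number a weaker inhibitor of growth), compound 2 `CCOC(=O)Nc1ccc([Se]C#N)cc1` gives 38000 nM, and compound 1 `CCCOC(=O)Nc1ccc([Se]C#N)cc1` gives 51900 nM, so compound 2 stands at one end of the two numbers measured so far, separated from compound 1 by a 1.4-fold lower number from compound 1 to compound 2 (0.14 log units; within the scatter). Compound 3 `N#C[Se]c1ccc(NC(=O)OCc2ccccc2)cc1` differs from compound 2 by phenyl in place of methyl on a saturated chain carbon bound to an oxygen next to a carbonyl group. Going by the values given here, the single measured step that bears on this part of the molecule, from compound 1 to compound 2, stayed within the scatter, and no step beyond the scatter is expected in this assay here either. Compound 3 is therefore estimated at 30000 nM, within a range of 8000 nM to 110000 nM, which would mean an expected step of a 1.3-fold lower number from compound 2 to compound 3 (0.10 log units; within the scatter).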

Compound 3, concentration for total growth inhibition: 41200 nM
Compound 3: middle estimate off by 1.4-fold (0.14 log units), on the low side; measured number inside the range.
By their numbers in this assay, from the lowest: compounds 2, 3 and 1 (each within the scatter of the next).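

In this assay, phenyl in place of methyl on a saturated chain carbon bound to an oxygen next to a carbonyl group gives a 1.1-fold higher number from compound 2 to compound 3 (0.04 log units; within the scatter), and phenyl in place of ethyl at that place gives a 1.3-fold lower number from compound 1 to compound 3 (0.10 log units; within the scatter). The earlier compounds shown here compared only short chains here; these steps show that an aromatic ring can stand at this place without a change beyond the scatter. No measurement given here explains this result. From the compounds shown here alone, whether an amine or a carboxylic acid at this place would give a step beyond the scatter remains open, and so does the effect of a longer chain.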